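The source may hold more compounds than are shown below. What is called first, only, known or untested is meant among the compounds shown, and "the series" means these compounds.

Compound 1 `CCOc1c(-c2occ(C)c2C(=O)O)ccc2c(CC)cccc12` gives a limit of > 10 ug/mL in a functional assay on SK-BR-3 cells (Homo sapiens) for cytotoxicity, read by MTT assay, with a stated time of 72 h; on this read-out higher numbers stand for an effect only at larger amounts of compound and lower numbers for an effect already at smaller amounts.
Compound 2 `CCCOC(=O)c1c(C)coc1-c1ccc2c(CC)cccc2c1OC` likewise gives only a limit, > 10 ug/mL.
Compound 3 `CCOc1c(-c2occ(C)c2CO)ccc2c(CC)cccc12` gives 8.8 ug/mL.

Compound 2 therefore stands at the limit of > 10 ug/mL in this assay, at which 2 of the 3 values shown sit, so no number is known for it, only that its effect appears beyond the tested amounts. The change leading to compound 4 `CCc1cccc2c(OC)c(-c3occ(C)c3COC(C)=O)ccc12` is acetoxymethyl in place of propoxycarbonyl on an aromatic carbon. For the measured compounds named here, no measured step covers this change directly. Going by the values given here, the only measured step, an at least 1.1-fold lower number from compound 1 to compound 3 (0.05 log units; that floor lies within the scatter), concerns a different change and lies within the scatter, so it gives no sign of a shift in this assay. On this basis no step beyond the scatter is expected, and the step to compound 4 is estimated as an at least 1.1-fold lower number from compound 2 to compound 4 (0.04 log units; that floor lies within the scatter). Compound 4 is thus expected to give about 9 ug/mL, within a range from 4 ug/mL to 20 ug/mL, with a fair chance that this assay again reports only a limit.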

Compound 4, concentration for half-maximal effect: > 10 ug/mL
Compound 4 gave a limit, no number (the forecaster's own chance of this, stated with the estimate: 50%); middle value at least 1.1-fold (0.04 log units) from the limit.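

For the compounds shown here, compound 2 and compound 4 both give only a limit in this assay, so no step between them can be read. The compounds shown leave open whether acetoxymethyl in place of propoxycarbonyl shifts this read-out at all, and in which direction.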